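The compounds below may be only part of what the source reports. "The series", "measured", "known", "first", "only" and "open" are said of these compounds alone.

In an ADME assay on MDCK cells (Canis lupus familiaris) for cytotoxicity, read by MTT assay, with a stated time of 48 h (on this read-out higher numbers stand for lower toxicity in this test and lower numbers for higher toxicity in this test), compound 1 `CCCOc1ccc(C(=O)Nc2nc3nc(-c4ccccc4)cc(C)n3n2)cc1` gives 247000 nM. Compound 2 `Cc1cc(-c2ccccc2)nc2nc(NC(=O)c3ccccc3F)nn12` gives > 250000 nM, which is a limit of the assay and not a number. This is the position described by the limit of > 250000 nM in this assay, at which 1 of the 2 values shown sits, so compound 2 offers a boundary rather than a fixed starting point. Compound 3 `Cc1cc(-c2ccccc2)nc2nc(NC(=O)c3ccc(N)cc3)nn12` keeps the core of compound 2 and differs in one place: 4-aminophenyl in place of 2-fluorophenyl on a carbonyl carbon. Put simply, 4-aminophenyl stands in place of 2-fluorophenyl on a carbonyl carbon. Among the compounds with values here, no measured pair shows the effect of this exchange. Compound 1 carries a different group on its carbonyl and gives 247000 nM, so only a small move toward lower numbers is expected in this assay, perhaps none beyond the usual scatter. The estimated step of an at least 1.3-fold lower number from compound 2 to compound 3 (0.11 log units; that floor lies within the scatter) is therefore modest. For compound 3 the expected value is 190000 nM, with an estimated range from 90000 nM to 250000 nM.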

Compound 3, half-maximal cytotoxic concentration: > 250000 nM
Compound 3: no number, only a limit; the forecaster's own chance of this, stated with the estimate: 40%; middle value at least 1.3-fold (0.11 log units) away from the limit.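

Compound 3 gives > 250000 nM in this assay, which is again a limit of the assay and not a number, so 4-aminophenyl on this carbonyl carbon leaves the compound at the same limit as 2-fluorophenyl, and the step between these two limits cannot be read. Amino in place of propoxy on an aromatic carbon gives an at least 1.0-fold higher number from compound 1 to compound 3 (0.00 log units; that floor lies within the scatter), so this exchange shows no separation beyond the usual scatter. The compounds shown now gather at a single boundary: the limit of > 250000 nM in this assay, at which 2 of the 3 values shown sit.

Going by these compounds, the true values of compound 2 and compound 3 remain unknown, so it stays open whether these two groups differ at all in this test. On these data alone, it is also open whether a carboxylic acid or a butoxy chain on that aromatic carbon would give a clearly lower number.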